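From benzyl to phenyl when only limits are known

This account rests on a few compounds, and the source may have more. Where it says the series, first, only, none or still open, it means among the compounds named here.

Three related compounds have been tested in a physicochemical assay for solubility, using the shake flask method, measured as kinetic solubility, with a stated time of 2 h, at pH 7.4 (on this read-out lower numbers stand for lower solubility and higher numbers for higher solubility), and none gives a true number. Compound 2 `CN(Cc1ccccc1)c1cc(C(=O)Nc2ccccc2)ncn1` is the starting point here. In this assay compound 2 gives < 5000 nM, which is a limit and not a number. Compound 1 `COc1ccc(NC(=O)c2cc(N(C)Cc3ccccc3)ncn2)cc1`, which carries a methoxy group, gives < 5000 nM, also a limit. Compound 3 `O=C(Nc1ccccc1)c1cc(NCc2ccccc2)ncn1` gives < 5000 nM, again a limit. The whole series therefore shares one reading: the limit of < 5000 nM in this assay, at which 3 of the 3 values shown sit.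

Compound 4 `CN(c1ccccc1)c1cc(C(=O)Nc2ccccc2)ncn1` differs from compound 2 in one place: phenyl in place of benzyl on a nitrogen on an aromatic ring. Put simply, this is phenyl in place of benzyl on a nitrogen on an aromatic ring. The closest measured change, at that same nitrogen, is a step that the two limits leave unreadable from compound 2 to compound 3. The other measured change is a step that the two limits leave unreadable from compound 1 to compound 2. Neither gives a size or a direction to carry over, so no step beyond the usual scatter is expected in this assay. The expected change is a step that the limit leaves unreadable from compound 2 to compound 4. The most likely outcome is another reported limit because of the limit of < 5000 nM in this assay, at which 3 of the 3 values shown sit. Compound 4 is estimated at 3000 nM, with an expected range from 1000 nM to 6000 nM.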

Compound 4, solubility: < 5000 nM
Compound 4 was reported as a limit (the forecaster's own chance of this, stated with the estimate: 85%); the middle value is on the limit's open side.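

Among these compounds, compound 2 and compound 4 are both reported only as limits in this assay, and no step between them can be read, in size or in direction. The compounds shown leave open where any true value lies, and whether phenyl in place of benzyl changes it at all, because all four share one reading: the limit of < 5000 nM in this assay, at which 4 of the 4 values shown sit.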